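Swapping the group on the ring nitrogen of compound 1

The source may hold more compounds than are shown below. What is called first, only, known or untested is meant among the compounds shown, and "the series" means these compounds.

Compound 1 `CCOC(=O)C1=Cc2ccccc2OC1(OCc1cn(CC(=O)Nc2ccc(OC)cc2)nn1)C(F)(F)F`: 31900 nM
Compound 2 `O=C(O)C1=Cc2ccccc2OC1(OCc1cc(-c2ccc3ccccc3c2)no1)C(F)(F)F`: > 150000 nM
Compound 3 `O=C(O)C1=Cc2ccccc2OC1(OCc1cc(-c2ccc(F)cc2F)no1)C(F)(F)F`: > 150000 nM

Within the data shown here, in a functional assay on HeLa cells (Homo sapiens) for inhibition, read by MTT assay, with a stated time of 24 h (a lower number here means a stronger inhibitor, a higher number a weaker inhibitor), compound 1 gives 31900 nM, the only number among the three. Compound 2 reaches only a limit of the assay, > 150000 nM. Compound 3 likewise stops at a limit, > 150000 nM. Among the measured compounds shown here, compound 1 therefore stands as the one compound with a measured value, and no ordering among the three can be read. For the measured compounds named here, the one measured step, a step that the two limits leave unreadable from compound 2 to compound 3, is unreadable because both of its ends sit at the limit of > 150000 nM in this assay, at which 2 of the 3 values shown sit.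

Compound 4 `CCOC(=O)C1=Cc2ccccc2OC1(OCc1cn(-c2cccc(C(F)(F)F)c2)nn1)C(F)(F)F` differs from compound 1 by 3-(trifluoromethyl)phenyl in place of ((4-methoxyphenyl)carbamoyl)methyl on an aromatic nitrogen. Going by the values given here, no measured step touches this position or this kind of exchange; the step from compound 2 to compound 3 concerns another ring and gives no size. The expectation for compound 4 therefore rests on compound 1 alone, and no step beyond the scatter is expected, a 1.1-fold lower number from compound 1 to compound 4 (0.03 log units; within the scatter). Compound 4 is estimated at 30000 nM, with a wide range from 7000 nM to 130000 nM.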

Compound 4, half-maximal inhibitory concentration: > 150000 nM
Compound 4 gave a limit, no number; the forecaster's own chance of this, stated with the estimate: 25%; at least 5.0-fold (0.69 log units) between middle value and limit.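

Among these compounds, at the aromatic nitrogen of the five-membered ring, the exchange gives the first readable step in this assay, an at least 4.7-fold higher number from compound 1 to compound 4 (0.67 log units; beyond the scatter), so the group on that nitrogen does affect the read-out. Both groups carry one six-membered aromatic ring of carbon only, so that ring alone does not keep the measured level of compound 1. Compound 4 gives a limit, not a number, which leaves the full size of the step unknown, and that limit is shared by most of the series: the limit of > 150000 nM in this assay, at which 3 of the 4 values shown sit.

The compounds shown do not separate the contribution of the carbamoyl methyl link from that of the 4-methoxyphenyl end. Going by these compounds, how a simple amine, a morpholine ring or a longer carbon chain on that nitrogen would read remains open.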